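Dithiane to hydroxy at the quaternary ring carbon

A few compounds are considered here, and "the series" means these few. Any claim that something is new, unique, unknown or untested is made for them only; others in the source may bear on it.

Compound 1 `CC(=O)O[C@@H]1OC(=O)[C@](C)(C(C)=O)[C@@H]1C` gives 7000 nM in a functional assay on DA-3 cells for cytotoxicity against DA-3 cell line (Mus musculus), read by MTT assay; on this read-out lower numbers stand for stronger inhibition and higher numbers for weaker inhibition. Compound 2 `CC(=O)O[C@@H]1OC(=O)[C@@](C(C)=O)(C2SCCCS2)[C@@H]1C` reaches only the limit of this assay, > 50000 nM, so for compound 2 there is a bound and no number. For the measured compounds named here, the one measured step, an at least 7.1-fold higher number from compound 1 to compound 2 (0.85 log units; beyond the scatter), thus shows a weakening when the dithiane enters on the saturated ring carbon, and its size is known only as a lower bound because one of the two values sits at the limit of > 50000 nM in this assay, at which 1 of the 2 values shown sits. Compound 3 `CC(=O)O[C@@H]1OC(=O)[C@](O)(C(C)=O)[C@@H]1C` is not yet measured. The change to it is one oxygen atom in place of a group of 6 heavy atoms (4 carbon, 2 sulfur; one six-membered non-aromatic ring with 2 hetero atoms), on a saturated ring carbon; in words, one oxygen atom in place of a group of 6 heavy atoms (4 carbon, 2 sulfur; one six-membered non-aromatic ring with 2 hetero atoms), on a saturated ring carbon. This undoes the bulky entry that the step from compound 1 to compound 2 penalised, and substitutes a small hydroxy group for the methyl of compound 1. The step is therefore expected to run downward, toward the number of compound 1, as an at least 4.1-fold lower number from compound 2 to compound 3 (0.61 log units; beyond the scatter). For compound 3 the estimate in this assay is 12000 nM, within 3000 nM to 50000 nM.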

Compound 3, half-maximal inhibitory concentration: > 50000 nM
Compound 3 gave a limit, no number; the forecaster's own chance of this, stated with the estimate: 30%; middle value at least 4.1-fold (0.61 log units) away from the limit.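

In this assay compound 3 gives only a limit, > 50000 nM, and not a number. Hydroxy in place of methyl on the saturated ring carbon produces an at least 7.1-fold higher number from compound 1 to compound 3 (0.85 log units; beyond the scatter), so the weakening at this position is not confined to the dithiane of compound 2: it also appears with an entering group of a single heavy atom. Compound 2 and compound 3 cannot be ordered against each other, and the step between them cannot be read: the limit of > 50000 nM in this assay, at which 2 of the 3 values shown sit.

Of the three groups shown at this ring carbon, only the methyl of compound 1 gives a number, so the series does not yet tell whether any other group here can stay clear of the limit. Ethyl, methoxy, an amine or a fluorine atom on this carbon, with the rest of the core of compound 1 unchanged, would show whether the number depends on methyl itself or whether other small groups give a readable value as well.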